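Replacing the pyridine ring with a carboxyphenyl group

The source may report more compounds than this note shows. Statements on the series, on what has been measured and on what is new or still open speak of the compounds shown alone.

Two compounds share a core and were tested in an assay on HEK293 cells for antagonist activity at transient receptor potential M8 protein (Canis lupus familiaris), read by fluorescence and calcium flux, with a stated time of 5 min; on this read-out higher numbers stand for weaker inhibition and lower numbers for stronger inhibition. Compound 1 `COc1ccccc1C1CCCN1C(=O)C(Nc1ccccc1F)c1ccc(C(F)(F)F)cc1` gives 12 nM, and compound 2 `O=C(C(Nc1ccccc1F)c1ccc(C(F)(F)F)cc1)N1CCCC1c1ccccn1` gives 25 nM. Within the data shown here, the one measured step, a 2.1-fold higher number from compound 1 to compound 2 (0.32 log units; beyond the scatter), puts compound 2 at the higher of the two numbers. Compound 3 `O=C(O)c1ccc(C2CCCN2C(=O)C(Nc2ccccc2F)c2ccc(C(F)(F)F)cc2)cc1` is not yet measured; it differs from compound 2 by 4-carboxyphenyl in place of pyridin-2-yl on a saturated ring carbon. Among the measured compounds shown here, no measured step covers a 4-carboxyphenyl group, so the only guidance is that exchanging the aromatic group on this saturated ring carbon shifted the number modestly, as seen in the step from compound 1 to compound 2. A further exchange of similar kind is therefore expected to move the number beyond the scatter, though with little certainty about direction. For compound 3 the estimated step is a 2.8-fold higher number from compound 2 to compound 3 (0.45 log units; beyond the scatter). The expected value for compound 3 in this assay is 70 nM, within a range from 15 nM to 500 nM.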

Compound 3, half-maximal inhibitory concentration: 66 nM
Beside the measured number, compound 3's estimate is 1.1-fold (0.03 log units) above it; the measured number falls inside the stated range.
By their numbers in this assay, from the lowest: compound 1; then compound 2; then compound 3.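

In this assay the saturated ring carbon now carries a third aromatic group, and 4-carboxyphenyl, which brings a hydrogen-bond donor that pyridin-2-yl lacks, gives the highest number of the three, with a 2.6-fold higher number from compound 2 to compound 3 (0.42 log units; beyond the scatter) and a 5.5-fold higher number from compound 1 to compound 3 (0.74 log units; beyond the scatter) as its two steps. Both steps are beyond the scatter yet modest, so inhibition weakens at this position with a carboxylic acid on the ring but is not lost. No measurement shown here explains why the number rises.

Going by these compounds, the change swaps the ring and adds the acid at once, so the share of each stays open. A plain phenyl group, or a 4-aminophenyl group on the same carbon, would be needed to separate the ring from the group it carries.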